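The source may hold more compounds than are shown below. What is called first, only, known or untested is meant among the compounds shown, and "the series" means these compounds.

Compound 1 `Cc1cc(OCc2nc3ccccc3s2)ccc1NC(=O)Nc1ccc(Cl)c(Cl)c1` — 230 nM in an assay on isolated protein for inhibition of Polyunsaturated fatty acid 5-lipoxygenase (Homo sapiens), read by HPLC, with a stated time of 10 min; on this read-out lower numbers stand for stronger inhibition and higher numbers for weaker inhibition
Compound 2 `Cc1cc(NC(=O)Nc2ccc(Cl)c(Cl)c2)ccc1OCc1nc2ccccc2s1` — 2170 nM
Compound 3 `Cc1cc(NC(=O)Nc2cc(Cl)cc(Cl)c2)ccc1OCc1nc2ccccc2s1` — 720 nM

Among these three numbers, compound 2 stands highest. The nearest of the others is compound 3, reached by a 3.0-fold lower number from compound 2 to compound 3 (0.48 log units; beyond the scatter) through 3,5-dichlorophenyl in place of 3,4-dichlorophenyl on an amide-type nitrogen. Compound 1 has the lowest of the three numbers, but it differs from compound 2 in how the groups are arranged rather than in a single place, so its value is simply noted alongside.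

Compound 4 `O=C(Nc1ccc(OCc2nc3ccccc3s2)cc1)Nc1ccc(Cl)c(Cl)c1` is compound 2 altered in one place: hydrogen in place of methyl on an aromatic carbon. For the measured compounds named here, no measured step touches this methyl. Going by the values given here, the single measured step, a 3.0-fold lower number from compound 2 to compound 3 (0.48 log units; beyond the scatter), concerns the dichlorophenyl and says nothing about the methyl. There is therefore no measured guide for this change, and the plainest expectation is a step within the scatter, in neither direction. On that basis, compound 4 is expected to give about 2000 nM in this assay, within a range from 700 nM to 6000 nM. Compared with compound 2, this estimate amounts to a 1.1-fold lower number from compound 2 to compound 4 (0.04 log units; within the scatter), an expected difference that would not stand out from repeated measurement.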

Compound 4, half-maximal inhibitory concentration: 570 nM
Compound 4: the middle estimate sits 3.5-fold (0.55 log units) above what was measured, and the stated range ends above it.
By their numbers in this assay, from the lowest: compound 1; then compounds 4 and 3 (each within the scatter of the next); then compound 2.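

In this assay, the methyl on this aromatic carbon is not a neutral passenger, as taking it away gives a 3.8-fold lower number from compound 2 to compound 4 (0.58 log units; beyond the scatter). Set against the other methyl-bearing compound, the same swap of hydrogen for methyl runs the opposite way, giving a 2.5-fold higher number from compound 1 to compound 4 (0.39 log units; beyond the scatter), so the two methyl placements on the six-membered aromatic ring pull the number in opposite directions relative to the compound with no methyl: a methyl on this ring cannot be judged without saying which carbon carries it, and the earlier compounds, with no methyl-free partner, could not show that. Nothing available here explains why the placement matters in this way.

The compounds shown cover only methyl and hydrogen on these ring carbons, so it remains open whether an ethyl, a methoxy or a fluorine at either carbon would follow the same opposite trends. From the compounds shown here alone, it also remains open whether the gain seen with the 3,5-dichlorophenyl group, a 3.0-fold lower number from compound 2 to compound 3 (0.48 log units; beyond the scatter), would carry over to a partner with hydrogen in place of the methyl.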